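Swapping Trifluoromethyl for Propyl: Expected Cell Toxicity

This account rests on a few compounds, and the source may have more. Where it says the series, first, only, none or still open, it means among the compounds named here.

Measured compounds:
Compound 1 `CCCCCOc1nc(N)nc2c1ncn2/C=C1/CC1(CO)CO`: > 20000 nM
Compound 2 `Nc1nc(OCC(F)(F)F)c2ncn(/C=C3/CC3(CO)CO)c2n1`: > 20000 nM
Compound 3 `Nc1nc2c(ncn2/C=C2/CC2(CO)CO)c(=O)[nH]1`: > 20000 nM

All three values in an ADME assay on CCRF-HSB-2 cells (Homo sapiens) for cytotoxicity, with a stated time of 7 days (on this read-out lower numbers stand for higher toxicity in this test and higher numbers for lower toxicity in this test), are limits of the assay rather than numbers. Compound 2 therefore stands at the limit of > 20000 nM in this assay, at which 3 of the 3 values shown sit, with every measured compound sitting there too. For the measured compounds named here, the only step between measured compounds that differ in one place, a step that the two limits leave unreadable from compound 1 to compound 2, cannot be read, since both ends are limits.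

Compound 4 `CCCCOc1nc(N)nc2c1ncn2/C=C1/CC1(CO)CO` differs from compound 2 by propyl in place of trifluoromethyl on a saturated chain carbon bound to an oxygen on an aromatic ring. Cut one bond further out, this reads 2,2,2-trifluoroethoxy to butoxy. Going by the values given here, compound 1 already carries a longer chain at the same place and still sits at the limit, so nothing among the measured compounds points to a readable shift in either direction. The expected step that the limit leaves unreadable from compound 2 to compound 4 is accordingly none beyond the scatter. Compound 4 is estimated at 30000 nM, within a range from 15000 nM to 80000 nM, and is most likely to be reported again as a limit.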

Compound 4, half-maximal cytotoxic concentration: > 20000 nM
Compound 4: a limit, no number (the forecaster's own chance of this, stated with the estimate: 85%); the middle value lies beyond the limit too.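

In this assay compound 4 gives > 20000 nM, which is a limit of the assay and not a number. Its steps from compound 1 and from compound 2 therefore cannot be read. The compounds shown leave open whether these chains differ at all in their toxicity to these cells.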